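Hydroxy in place of bromo on the shared core

The source may report more compounds than this note shows. Statements on the series, on what has been measured and on what is new or still open speak of the compounds shown alone.

In a functional assay on SW480 cells (Homo sapiens) for antiproliferative activity, read by MTT assay, with a stated time of 48 h (a lower number here means a stronger inhibitor, a higher number a weaker inhibitor), compound 1 `Nc1ccc(OCc2cn(-c3cc(=O)oc4ccc(Br)cc34)nn2)cc1` gives 2090 nM and compound 2 `O=c1cc(-n2cc(COc3ccc(F)cc3)nn2)c2cc(Br)ccc2o1` gives 1770 nM. Within the data shown here, compound 2 therefore stands level with its only neighbour, since a 1.2-fold lower number from compound 1 to compound 2 (0.07 log units; within the scatter) stays within the scatter. Compound 3 `O=c1cc(-n2cc(COc3ccc(F)cc3)nn2)c2cc(O)ccc2o1` has hydroxy in place of bromo on an aromatic carbon. That single measured step, fluoro in place of amino on an aromatic carbon, changes another place and offers no direct guide to this swap. A cautious estimate in this assay is an expected 2.3-fold higher number from compound 2 to compound 3 (0.35 log units; beyond the scatter), toward a weaker inhibitor. Compound 3 is expected at 4000 nM, with an estimated range of 1500 nM to 12000 nM.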

Compound 3, half-maximal inhibitory concentration: 2720 nM
Estimate against measurement, compound 3: 1.5-fold (0.17 log units) above; the measured number falls inside the stated range.
By their numbers in this assay, from the lowest: compounds 2, 1 and 3 (each within the scatter of the next).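

Among these compounds, compounds 1 and 2 both carry bromo, so this is the first step that tests this position on the shared core. Hydroxy in place of bromo gives a 1.5-fold higher number from compound 2 to compound 3 (0.19 log units; within the scatter) in this assay and so the position accepts a hydrogen-bond donor and acceptor without a step beyond the scatter. No evidence at hand accounts for this result.

From the compounds shown here alone, whether methoxy or an amine at this position would also stay within the scatter of bromo remains open. So does the outcome for a longer chain there.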